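This account rests on a few compounds, and the source may have more. Where it says the series, first, only, none or still open, it means among the compounds named here.

Measured so far in an ADME assay on HepG2 2.2.15 cells (Homo sapiens) for cytotoxicity, read by MTT assay; a higher number here means that more compound is tolerated, a lower number that less compound is tolerated:
- Compound 1 `C=C1CC[C@@H]2[C@](C)(COC(=O)/C=C/c3cccc(OC)c3)[C@H](O)CC[C@@]2(C)[C@@H]1/C=C/C1=CCOC1=O`: > 1970000 nM
- Compound 2 `C=C1CC[C@@H]2[C@](C)(CO)[C@H](OC(=O)/C=C/c3ccccc3)CC[C@@]2(C)[C@@H]1C/C=C1\C=COC1=O`: 179000 nM

Compound 1 reads > 1970000 nM, which is a limit of the assay and not a number. Within the data shown here, that leaves compound 2, at 179000 nM, as the only true number in this assay so far, and so the one firm reference point.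

The next compound to be tested is compound 3 `C=C1CC[C@@H]2[C@](C)(CO)[C@H](OC(=O)/C=C/c3cc(OC)c(OC)c(OC)c3)CC[C@@]2(C)[C@@H]1C/C=C1\C=COC1=O`. It keeps the shared core of compound 2 and changes one group, with 3,4,5-trimethoxyphenyl in place of phenyl on a double-bonded chain carbon bound to a double-bonded chain carbon.

Among the measured compounds shown here, no pair of measured compounds differs in just one place, so the data give no direct measure of what a swap like this does. The starting point is therefore compound 2 at 179000 nM, with no shift beyond the usual scatter of the assay expected in either direction. The expected step of a 1.2-fold higher number from compound 2 to compound 3 (0.09 log units; within the scatter) is an estimate that carries wide uncertainty. For compound 3 the estimated value is 220000 nM, with an expected range from 90000 nM to 700000 nM.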

Compound 3, half-maximal cytotoxic concentration: 211000 nM
Beside the measured number, compound 3's estimate is 1.0-fold (0.02 log units) above it, and the stated range covers the measured number.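

Replacing phenyl with 3,4,5-trimethoxyphenyl on a double-bonded chain carbon bound to a double-bonded chain carbon gives a 1.2-fold higher number from compound 2 to compound 3 (0.07 log units; within the scatter) in this assay, the first direct reading of a single swap among these compounds. At this position, a group of 6 heavy atoms with 0 hydrogen-bond acceptors can therefore give way to one of 12 heavy atoms with 3 hydrogen-bond acceptors, with no change in this read-out beyond the usual scatter. Nothing measured here explains that outcome.

Among these compounds, compound 1 reads > 1970000 nM, which is a limit of the assay, and it differs from compound 2 in more than one place, so it adds no further step. This single swap also leaves open whether the same position would tolerate a phenyl ring carrying an amine or a carboxylic acid, or a longer chain in place of the ring, and whether the same swap would read alike on a different core.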